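This account rests on a few compounds, and the source may have more. Where it says the series, first, only, none or still open, it means among the compounds named here.

Of the compounds shown here, three have so far been tested in an assay for inhibition of Voltage-dependent L-type calcium channel subunit alpha-1C (Rattus norvegicus), read by patch clamp, tested at 10 uM; a higher number here means more inhibition at the concentration tested (going by the name of the read-out), a lower number less inhibition. Compound 1 `CC1=C(C(=O)OCC(C)C)C(c2cc([N+](=O)[O-])ccc2O)C2=C(CCC(C)(C)C2=O)N1` gives 70%. Compound 2 `CC1=C(C(=O)OCC(C)C)C(c2cc([N+](=O)[O-])cc(Br)c2O)C2=C(CC(C)(C)CC2=O)N1` gives 70%, and compound 3 `CC1=C(C(=O)OCC(C)C)C(c2cc([N+](=O)[O-])ccc2O)C2=C(CC(C)(C)CC2=O)N1` gives 30%. Compound 3 and compound 2 differ in one place, (bromo in place of hydrogen on an aromatic carbon), and the step of a number 40 percentage points higher from compound 3 to compound 2 (beyond the scatter). Compound 1 and compound 2 lie within the scatter of each other, while compound 1 stands beyond the scatter of compound 3. The cores of compound 1 and compound 3 hold the same atoms joined differently; the difference between the two cores is not broken down here. Compound 4 `CC1=C(C(=O)OCC(C)C)C(c2cc([N+](=O)[O-])cc(Br)c2O)C2=C(CCC(C)(C)C2=O)N1` is not yet measured; it differs from compound 1 by bromo in place of hydrogen on an aromatic carbon, the same change seen between compound 3 and compound 2. Because that earlier step a number 40 percentage points higher from compound 3 to compound 2 (beyond the scatter) was large, a rise is expected here too. Since compound 1 already stands high, the step to compound 4 is expected to be smaller, a number 12 percentage points higher from compound 1 to compound 4 (beyond the scatter). Compound 4 is therefore estimated at 82%, between 62% and 96%.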

Compound 4, a percentage reported as inhibition, at one concentration (the size of the read-out at that concentration, not a potency): 15%
Compound 4: the middle estimate sits 67 percentage points above what was measured; measured number below the stated range.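

In this assay, bromo in place of hydrogen on an aromatic carbon, ortho to a hydroxy group, gives a step on the core of compound 1 that is a number 55 percentage points lower from compound 1 to compound 4 (beyond the scatter). The change therefore does not carry over between these two cores, and its direction reverses: the same change on two cores in this assay, a number 40 percentage points higher (beyond the scatter) from compound 3 to compound 2 and a number 55 percentage points lower (beyond the scatter) from compound 1 to compound 4, 95 percentage points apart, beyond the scatter of two such steps This shows that, for these two pairs, the outcome of the change depends on the core that bears it, but it does not show why the cores differ or how the change would behave on any further core.

The compounds shown leave open whether chloro or methyl at that place would split between the cores in the same way. As far as these compounds go, whether an amine in place of the nitro group would alter the result also remains open.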